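Swapping the lactam of compound 2 for a tetrazolylmethyl group

A few compounds are considered here, and "the series" means these few. Any claim that something is new, unique, unknown or untested is made for them only; others in the source may bear on it.

Of the compounds shown here, two sharing one core have been measured so far. Compound 1 `CC(C)NC(=O)CC(c1ccc(-c2ccc3cccc(F)c3c2)[nH]c1=O)C(C)C` gives 24200 nM in a physicochemical assay for solubility, measured as kinetic solubility, at pH 2; on this read-out higher numbers stand for higher solubility and lower numbers for lower solubility. Compound 2 `CC(C)C(c1ccc(-c2ccc3cccc(F)c3c2)[nH]c1=O)N1CCCCC1=O` gives 23500 nM in the same this assay. The step of a 1.0-fold lower number from compound 1 to compound 2 (0.01 log units; within the scatter) shows that exchanging one carbonyl-bearing group for another left the solubility unchanged, and the two numbers sit within the scatter of each other, so neither compound stands apart.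

Compound 3 `CC(C)C(Cc1nnn[nH]1)c1ccc(-c2ccc3cccc(F)c3c2)[nH]c1=O` is not yet measured. It differs from compound 2 as follows: (1H-tetrazol-5-yl)methyl in place of 2-oxopiperidin-1-yl on a saturated chain carbon bound to an aromatic carbon and a saturated chain carbon. Within the data shown here, the only measured step replaced one neutral group by another and produced no movement, but no measured pair tests a tetrazole ring in this place, so the expectation rests on that single flat step alone. The number for compound 3 is therefore expected to stay near that of compound 2, with an estimated step of a 1.1-fold lower number from compound 2 to compound 3 (0.03 log units; within the scatter). The estimate for compound 3 in this assay is 22000 nM, with a range from 7000 nM to 60000 nM.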

Compound 3, solubility: 28000 nM
Estimate against measurement, compound 3: 1.3-fold (0.10 log units) below; low and high end bracket the measured number.
By their numbers in this assay, from the lowest: compounds 2, 1 and 3 (each within the scatter of the next).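

Among these compounds, at the place on a saturated chain carbon bound to an aromatic carbon and a saturated chain carbon, this assay now tests an aromatic tetrazole ring with a hydrogen-bond donor, a kind of group the earlier compounds lacked, and it gives a 1.2-fold higher number from compound 2 to compound 3 (0.08 log units; within the scatter). The comparison with the amide side chain gives a 1.2-fold higher number from compound 1 to compound 3 (0.06 log units; within the scatter), so on this read-out the three side chains cannot be told apart, even though the entering ring differs from the lactam in ring type and in its counts of hydrogen-bond donors and acceptors. No measured evidence is available to explain this result.

The compounds shown leave open whether an amine, a carboxylic acid or a longer chain at this place would move the number beyond the scatter. They also leave open whether these three side chains would stay level at a different pH.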